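Aryl amide variation on a shared core in growth inhibition

This account rests on a few compounds, and the source may have more. Where it says the series, first, only, none or still open, it means among the compounds named here.

Compound 1 `O=C(COc1ccc(/C=C2\SC(=O)NC2=O)cc1)Nc1ccc([N+](=O)[O-])cc1`: in a functional assay on PC-3 cells (Homo sapiens) for inhibition (on this read-out lower numbers stand for stronger inhibition of growth and higher numbers for weaker inhibition of growth), compound 1 gives > 100000 nM, a limit of the assay.
Compound 2 `O=C(COc1ccc(/C=C2\SC(=O)NC2=O)cc1)Nc1ccccc1`: in this assay compound 2 gives > 100000 nM, a limit of the assay.
Compound 3 `Cc1cc(Br)ccc1NC(=O)COc1ccc(/C=C2\SC(=O)NC2=O)cc1`: in this assay compound 3 gives > 100000 nM, a limit of the assay.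

All three measured compounds sit at the same limit (the limit of > 100000 nM in this assay, at which 3 of the 3 values shown sit), so compound 3 stands nowhere distinguishable from the others. The steps a step that the two limits leave unreadable from compound 1 to compound 2, a step that the two limits leave unreadable from compound 1 to compound 3 and a step that the two limits leave unreadable from compound 2 to compound 3 are therefore unreadable in size and direction. Compound 4 `O=C(COc1ccc(/C=C2\SC(=O)NC2=O)cc1)Nc1ccc(F)cc1F` differs from compound 3 by 2,4-difluorophenyl in place of 4-bromo-2-methylphenyl on an amide-type nitrogen. No measured step bears readably on this change, and every aryl amide shown so far has stayed at the limit in this assay. Compound 4 is therefore expected to give about 150000 nM in this assay, most likely reported again as a limit, within a range from 40000 nM to 500000 nM. The expected step that the limit leaves unreadable from compound 3 to compound 4 is estimated to stay within the scatter.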

Compound 4, concentration for 50% growth inhibition: > 100000 nM
Compound 4: a limit, no number; the forecaster's own chance of this, stated with the estimate: 80%; the middle value lies beyond the limit too.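

For the compounds shown here, compound 4 sits at a limit of the assay, as do compound 1, compound 2 and compound 3, so no step among them can be read in size or direction: the limit of > 100000 nM in this assay, at which 4 of the 4 values shown sit. The compounds shown leave open whether any aryl group on the amide-type nitrogen gives a measurable value in this assay.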